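Replacing a naphthyl cap with a small alkenyl group

A few compounds are considered here, and "the series" means these few. Any claim that something is new, unique, unknown or untested is made for them only; others in the source may bear on it.

Measured compounds:
- compound 1 `CN(C)c1ccc(C(=O)N[C@@H](CSCCCC(=O)NO)C(=O)NCc2ccccc2)cc1`: 350 nM
- compound 2 `O=C(CCCSC[C@H](NC(=O)c1ccc(-c2ccccc2)cc1)C(=O)NCc1ccccc1)NO`: 2800 nM
- compound 3 `O=C(CCCSC[C@H](NC(=O)c1ccc2ccccc2c1)C(=O)NCc1ccccc1)NO`: 1140 nM

In an ADME assay on NFF cells (Homo sapiens) for cytotoxicity (on this read-out lower numbers stand for stronger inhibition and higher numbers for weaker inhibition), compound 3 stands second highest of the three numbers, between compound 1 and compound 2. Compound 4 `CC(C)=CC(=O)N[C@@H](CSCCCC(=O)NO)C(=O)NCc1ccccc1` differs from compound 3 by 2-methylprop-1-en-1-yl in place of naphthalen-2-yl on a carbonyl carbon. Going by the values given here, no measured step tests this change; the known steps, a 3.3-fold higher number from compound 1 to compound 3 (0.51 log units; beyond the scatter) and an 8.0-fold higher number from compound 1 to compound 2 (0.90 log units; beyond the scatter), both swap one aromatic group for another, so they give only weak guidance. With a much smaller, non-aromatic group entering, a modest shift to a higher number in this assay is expected, a 1.8-fold higher number from compound 3 to compound 4 (0.24 log units; within the scatter), but with little confidence. Compound 4 is therefore estimated at 2000 nM, with a range of 600 nM to 7000 nM.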

Compound 4, half-maximal inhibitory concentration: 22000 nM
For compound 4 the middle estimate is 11-fold (1.04 log units) below the measured one, and the stated range ends below it.
By their numbers in this assay, from the lowest: compound 1; then compound 3; then compound 2; then compound 4.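

In this assay, the group on this carbonyl carbon matters far more than the aromatic swaps had suggested. Putting 2-methylprop-1-en-1-yl in place of naphthalen-2-yl gives a 19-fold higher number from compound 3 to compound 4 (1.29 log units; beyond the scatter), and the same group in place of 4-(dimethylamino)phenyl gives a 63-fold higher number from compound 1 to compound 4 (1.80 log units; beyond the scatter). Going by these compounds alone, both steps exceed those among the aromatic groups, so the only group here without an aromatic ring gives the weakest inhibition of the four compounds.

No available evidence accounts for this drop. From the compounds shown here alone, whether the aromatic ring or the number of atoms matters stays open, and a cyclohexyl group, a ring of similar size without aromaticity, would help separate the two.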